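Adding a Second Chloro to the Hydrazone Aryl Ring

This account rests on a few compounds, and the source may have more. Where it says the series, first, only, none or still open, it means among the compounds named here.

Of the compounds shown here, two sharing one core have been measured in an ADME assay on NIH3T3 cells (Mus musculus) for cytotoxicity, read by MTT assay, with a stated time of 24 h; on this read-out higher numbers stand for weaker inhibition and lower numbers for stronger inhibition. Compound 1, `O=C(CSc1nnc(-c2ccncc2)o1)N/N=C/c1cccc(F)c1`, gives 205000 nM in this assay. Compound 2, `O=C(CSc1nnc(-c2ccncc2)o1)N/N=C/c1cc(Cl)ccc1O`, gives 166000 nM. Among the measured compounds shown here, the only step between them, a 1.2-fold lower number from compound 1 to compound 2 (0.09 log units; within the scatter), swaps the whole aryl ring on the hydrazone carbon and leaves the read-out within the scatter, so compound 2 and compound 1 cannot be told apart on these numbers; compound 2 simply stands alongside compound 1 as one of two values of similar size.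

Compound 3, `O=C(CSc1nnc(-c2ccncc2)o1)N/N=C/c1cc(Cl)cc(Cl)c1O`, is not yet measured. It differs from compound 2 by chloro in place of hydrogen on an aromatic carbon. For the measured compounds named here, no measured step adds a single chloro to an otherwise unchanged ring; the one step that touches this ring at all, a 1.2-fold lower number from compound 1 to compound 2 (0.09 log units; within the scatter), changed far more and still stayed within the scatter. On that basis the step from compound 2 to compound 3 is expected to be a 1.1-fold lower number from compound 2 to compound 3 (0.04 log units; within the scatter), not beyond the scatter. Compound 3 is therefore estimated to give 150000 nM in this assay, expected to fall between 60000 nM and 400000 nM.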

Compound 3, half-maximal inhibitory concentration: 171000 nM
Compound 3: the middle estimate sits 1.1-fold (0.06 log units) below what was measured; the measured number falls inside the stated range.
By their numbers in this assay, from the lowest: compounds 2, 3 and 1 (each within the scatter of the next).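

In this assay, among the compounds shown here, this is the first step that changes a single atom on an otherwise unchanged ring: chloro in place of hydrogen, on the aromatic carbon ortho to a hydroxy group and meta to a chloro group, gives a 1.0-fold higher number from compound 2 to compound 3 (0.01 log units; within the scatter), so this position takes a chloro with no readable shift in this read-out. The larger swap to the 3,5-dichloro-2-hydroxyphenyl ring in place of 3-fluorophenyl gives a 1.2-fold lower number from compound 1 to compound 3 (0.08 log units; within the scatter), which means that the two rings cannot be told apart here, whether or not this second chloro is present. No supporting evidence is available to explain why the read-out holds steady across these changes.

An amine, a carboxylic acid or a longer chain in place of this chloro could still shift the number, so the tolerance seen here covers only chloro and hydrogen at this position. On these data alone, the part played by the hydroxy group alone also stays open, as the one ring without it, in compound 1, differs from the others in more than one place.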